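Amide variation on a bis-indole alkaloid nitrile series

This account rests on a few compounds, and the source may have more. Where it says the series, first, only, none or still open, it means among the compounds named here.

Measured compounds:
compound 1 `CN1[C@@H]2c3[nH]c4ccccc4c3C[C@H]1[C@H](C#N)N1[C@@H](CNC(=O)c3ccc4ccccc4c3)c3[nH]c4ccccc4c3C[C@@H]21` — 4940 nM
compound 2 `CN1[C@@H]2c3[nH]c4ccccc4c3C[C@H]1[C@H](C#N)N1[C@@H](CNC(=O)c3cc4ccccc4o3)c3[nH]c4ccccc4c3C[C@@H]21` — 850 nM

Both compounds were read in a functional assay on HT-29 cells (Homo sapiens) for cytotoxicity, read by MTT assay, with a stated time of 72 h; on this read-out lower numbers stand for stronger inhibition and higher numbers for weaker inhibition. Going by the values given here, compound 2 holds the lowest number of the two measured; its nearest neighbour is compound 1, and the single measured step, a 5.8-fold lower number from compound 1 to compound 2 (0.76 log units; beyond the scatter), lies beyond the scatter, so the amide-bearing group does move the read-out.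

Compound 3 `COc1ccc(/C=C/C(=O)NC[C@H]2c3[nH]c4ccccc4c3C[C@H]3[C@H]4c5[nH]c6ccccc6c5C[C@@H]([C@H](C#N)N23)N4C)cc1` differs from compound 2 in 2-(4-methoxyphenyl)ethenyl in place of 1-benzofuran-2-yl on a carbonyl carbon. Among the compounds with values here, no measured step covers this exchange; the only step in hand, a 5.8-fold lower number from compound 1 to compound 2 (0.76 log units; beyond the scatter), shows that replacing one aryl group on that carbonyl by another can shift the number modestly in either direction, while the wider range of compound 1 marks how far a change here has reached so far. A move back toward weaker inhibition is therefore expected, of about a 2.4-fold higher number from compound 2 to compound 3 (0.37 log units; beyond the scatter), though a number near compound 2 cannot be ruled out. Compound 3 is estimated at 2000 nM, with a range from 600 nM to 7000 nM.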

Compound 3, half-maximal inhibitory concentration: 3060 nM
For compound 3 the middle estimate is 1.5-fold (0.18 log units) below the measured one; low and high end bracket the measured number.
By their numbers in this assay, from the lowest: compound 2; then compounds 3 and 1 (each within the scatter of the next).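

In this assay the step of a 3.6-fold higher number from compound 2 to compound 3 (0.56 log units; beyond the scatter) gives a second exchange on the carbonyl carbon that lies beyond the scatter, so the lowest number of the three stays with the 1-benzofuran-2-yl amide. The step of a 1.6-fold lower number from compound 1 to compound 3 (0.21 log units; within the scatter) lies within the scatter, so 2-(4-methoxyphenyl)ethenyl and naphthalen-2-yl cannot be told apart on this read-out, although only the former carries a double bond outside aromatic rings. Nothing in hand accounts for the gap between these two groups and 1-benzofuran-2-yl.

From the compounds shown here alone, whether the five-membered aromatic ring with its hetero atom is what sets compound 2 apart remains open. Equally open, going by these compounds, is how the read-out would respond to a non-aromatic group on the carbonyl carbon, such as cyclohexyl or a longer alkyl chain bearing an amine.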